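The source may report more compounds than this note shows. Statements on the series, on what has been measured and on what is new or still open speak of the compounds shown alone.

Measured in a functional assay on NB1 cells (Homo sapiens) for antiproliferative activity, with a stated time of 72 h; on this read-out higher numbers stand for weaker inhibition and lower numbers for stronger inhibition:
Compound 1 `Cc1ccc(NC(=O)CCN(Cc2ccc(C(=O)NO)cc2)C(=O)c2cc(C)cc(C)c2)cc1`: 670 nM
Compound 2 `O=C(CCN(Cc1ccc(C(=O)NO)cc1)C(=O)c1ccccc1)NCc1ccccc1`: 6660 nM

Of these two numbers, compound 2 has the higher, and the gap to compound 1 lies beyond the scatter. Compound 3 `Cc1ccc(NC(=O)CCN(Cc2ccc(C(=O)NO)cc2)C(=O)c2ccccc2)cc1` departs from compound 2 with 4-methylphenyl in place of benzyl on an amide-type nitrogen. Going by the values given here, no measured pair isolates this change, but compound 1, which also carries 4-methylphenyl, gives 670 nM, so a lower number is expected. The estimated step is a 3.7-fold lower number from compound 2 to compound 3 (0.57 log units; beyond the scatter), towards stronger inhibition and beyond the scatter. For compound 3 the expected value is 1800 nM, with an estimated range of 600 nM to 5000 nM.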

Compound 3, half-maximal inhibitory concentration: 1480 nM
Estimate against measurement, compound 3: 1.2-fold (0.09 log units) above, within the range that was stated.
By their numbers in this assay, from the lowest: compound 1; then compound 3; then compound 2.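

In this assay, 4-methylphenyl in place of benzyl on the amide-type nitrogen gives a 4.5-fold lower number from compound 2 to compound 3 (0.65 log units; beyond the scatter) with phenyl kept on the carbonyl carbon, so this nitrogen substituent matters on its own. Phenyl in place of 3,5-dimethylphenyl on the carbonyl carbon gives a 2.2-fold higher number from compound 1 to compound 3 (0.34 log units; beyond the scatter) with 4-methylphenyl kept, so both changes contribute to the gap between compound 1 and compound 2. Nothing at hand explains either step. The compounds shown leave open how 4-chlorophenyl or 2-phenylethyl would fare on that nitrogen. They also leave open whether a single methyl on the phenyl would match 3,5-dimethylphenyl.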